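Butyl for isopropyl on the amide of compound 1

The source may report more compounds than this note shows. Statements on the series, on what has been measured and on what is new or still open speak of the compounds shown alone.

Values in a functional assay on Huh-7 cells (Homo sapiens) for antiproliferative activity, read by CCK-8 assay, with a stated time of 72 h; a lower number here means a stronger inhibitor of growth, a higher number a weaker inhibitor of growth:
- compound 1 `CCC1C(=O)N(C)c2cnc(-n3ccc4cc(C(=O)NC(C)C)ccc43)nc2N1c1ccn(C)n1`: 6740 nM
- compound 2 `CCCNS(=O)(=O)c1ccc(Nc2ncc3c(n2)N(C2CCCC2)[C@H](CC)C(=O)N3C)cc1`: 278 nM
- compound 3 `CC[C@@H]1C(=O)N(C)c2cnc(Nc3ccc(S(N)(=O)=O)cc3)nc2N1C1CCCC1`: 1300 nM

Compound 1 has the highest number of the three, with compound 3 nearest and compound 2 furthest. Compound 4 `CCCCNC(=O)c1ccc2c(ccn2-c2ncc3c(n2)N(c2ccn(C)n2)C(CC)C(=O)N3C)c1` is not yet measured. Its difference from compound 1 is butyl in place of isopropyl on an amide-type nitrogen. For the measured compounds named here, only one measured step bears on this, and only loosely: a 4.7-fold higher number from compound 2 to compound 3 (0.67 log units; beyond the scatter), with hydrogen in place of propyl on a sulfonamide nitrogen. That step concerns a different nitrogen and loses the chain, whereas here one chain replaces another. A small move toward a lower number is therefore expected in this assay, possibly none beyond the scatter. The expected step is a 1.5-fold lower number from compound 1 to compound 4 (0.18 log units; within the scatter). The estimate for compound 4 is 4500 nM, with an expected range from 1700 nM to 11000 nM.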

Compound 4, concentration for 50% growth inhibition: 8670 nM
The estimate for compound 4 lay 1.9-fold (0.28 log units) below the measured number; low and high end bracket the measured number.
By their numbers in this assay, from the lowest: compound 2; then compound 3; then compounds 1 and 4 (each within the scatter of the next).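

In this assay butyl in place of isopropyl on the amide-type nitrogen gives a 1.3-fold higher number from compound 1 to compound 4 (0.11 log units; within the scatter) so the two chains cannot be told apart at this position. Unlike the sulfonamide step, which removes a propyl chain, this change replaces one carbon chain with another on the core of compound 1 and shows no difference beyond the scatter. No measured evidence accounts for this result. Still open, on these data alone, is whether a longer chain, a terminal amine or a terminal carboxylic acid on this amide nitrogen would separate from compound 1 beyond the scatter.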